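Chloro to bromo on the shared core

A few compounds are considered here, and "the series" means these few. Any claim that something is new, unique, unknown or untested is made for them only; others in the source may bear on it.

Measured in a functional assay on SW-620 cells (Homo sapiens) for antiproliferative activity, read by sulforhodamine B assay, with a stated time of 48 h (a higher number here means a weaker inhibitor, a lower number a stronger inhibitor), so far:
compound 1 `CO/N=C1/C(=O)N(CCCCCCC(=O)NO)c2ccccc21`: 730 nM
compound 2 `CO/N=C1/C(=O)N(CCCCCCC(=O)NO)c2ccc(F)cc21`: 1110 nM
compound 3 `CO/N=C1/C(=O)N(CCCCCCC(=O)NO)c2ccc(Cl)cc21`: 490 nM

Compound 3 cannot be separated from compound 1, since the chloro in place of hydrogen step a 1.5-fold lower number from compound 1 to compound 3 (0.17 log units; within the scatter) stays in the noise. It stands apart only from compound 2, and that step a 2.3-fold lower number from compound 2 to compound 3 (0.36 log units; beyond the scatter) is modest. Compound 4 `CO/N=C1/C(=O)N(CCCCCCC(=O)NO)c2ccc(Br)cc21` is still unmeasured and carries bromo in place of chloro on an aromatic carbon at the same place. Three steps at this carbon bear on it. The fluoro in place of hydrogen step a 1.5-fold higher number from compound 1 to compound 2 (0.18 log units; within the scatter) also lies within the scatter, so only one of the three goes beyond it, and only narrowly. For the measured compounds named here, no measured step involves bromo, so this rests on the other substituents alone. In this assay no change beyond the scatter is therefore expected, and no direction can be favoured. The expected step of a 1.0-fold lower number from compound 3 to compound 4 (0.02 log units; within the scatter) is small. For compound 4 the estimate is 470 nM with an expected range from 240 nM to 920 nM as its likely span.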

Compound 4, half-maximal inhibitory concentration: 2320 nM
For compound 4 the middle estimate is 4.9-fold (0.69 log units) below the measured one, outside the stated range (above it).
By their numbers in this assay, from the lowest: compounds 3, 1 and 2 (each within the scatter of the next, the first and the last beyond it); then compound 4.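

In this assay, for the compounds shown here, this carbon proves less forgiving than the earlier compounds suggested: with a 3.2-fold higher number from compound 1 to compound 4 (0.50 log units; beyond the scatter), bromo is the first group here to stand beyond the scatter from hydrogen. The largest step at this place falls between the two heavier halogens, a 4.7-fold higher number from compound 3 to compound 4 (0.68 log units; beyond the scatter), and with a 2.1-fold higher number from compound 2 to compound 4 (0.32 log units; beyond the scatter) compound 4 ends up as the weakest of the four, so the numbers do not run in order along fluoro, chloro and bromo, with compound 3 going against any such trend. Nothing available here accounts for this sharp difference between chloro and bromo.

As far as these compounds go, whether the weaker number is peculiar to bromo or also appears with other groups on this carbon, such as methyl, methoxy or an amine, remains open. So does whether the same exchange gives a similar step on the shared core with a longer chain.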